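One Added Methyl, Measured Once, Expected Again

The source may hold more compounds than are shown below. What is called first, only, known or untested is meant among the compounds shown, and "the series" means these compounds.

Compound 1 `COc1ccc(-c2cc(-c3cc4ccccc4o3)nc(OC)c2C#N)cc1` is tested in a functional assay on aorta (strain Wistar) for inhibition, with Thoracic aorta (Rattus norvegicus) as the target (on this read-out lower numbers stand for stronger inhibition and higher numbers for weaker inhibition), and gives 262000 nM. Compound 2 `CCOc1nc(-c2cc3ccccc3o2)cc(-c2ccc(OC)cc2)c1C#N` carries the change methyl in place of hydrogen on a saturated chain carbon bound to an oxygen on an aromatic ring and gives 204000 nM, which is a step of a 1.3-fold lower number from compound 1 to compound 2 (0.11 log units; within the scatter). Compound 3 `COc1ccc(-c2cc(-c3cc4ccccc4o3)nc(OC)c2C#N)c(OC)c1` differs from compound 1 in its core by methoxy in place of hydrogen on an aromatic carbon. In this assay compound 3 gives 425000 nM, a step of a 1.6-fold higher number from compound 1 to compound 3 (0.21 log units; within the scatter). Compound 4 `CCOc1nc(-c2cc3ccccc3o2)cc(-c2ccc(OC)cc2OC)c1C#N` is not yet measured; it differs from compound 3 by methyl in place of hydrogen on a saturated chain carbon bound to an oxygen on an aromatic ring, the same change that led from compound 1 to compound 2, at a place described in the same words. Because a 1.3-fold lower number from compound 1 to compound 2 (0.11 log units; within the scatter) stayed within the scatter, a similarly small step is expected here, a 1.3-fold lower number from compound 3 to compound 4 (0.11 log units; within the scatter). Compound 4 is therefore estimated at 330000 nM, with a plausible range from 150000 nM to 700000 nM.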

Compound 4, half-maximal inhibitory concentration: 488000 nM
Estimate against measurement, compound 4: 1.5-fold (0.17 log units) below, within the range that was stated.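

Among the compounds shown here, replacing methoxy with ethoxy on the core of compound 3 gives a 1.1-fold higher number from compound 3 to compound 4 (0.06 log units; within the scatter), so the added methyl again makes no step that stands out from the scatter, and the two cores agree: the same change on two cores in this assay, a 1.3-fold lower number (0.11 log units; within the scatter) from compound 1 to compound 2 and a 1.1-fold higher number (0.06 log units; within the scatter) from compound 3 to compound 4, 1.5-fold (0.17 log units) apart, within the scatter of two such steps. The added methoxy, read on the ethoxy compounds, gives a 2.4-fold higher number from compound 2 to compound 4 (0.38 log units; beyond the scatter), which is beyond the scatter, yet its gap from the matching step on the methoxy compounds is not: the same change on two cores in this assay, a 1.6-fold higher number (0.21 log units; within the scatter) from compound 1 to compound 3 and a 2.4-fold higher number (0.38 log units; beyond the scatter) from compound 2 to compound 4, 1.5-fold (0.17 log units) apart, within the scatter of two such steps. Both changes therefore carried across these two cores, but two cores are a narrow test, and this does not show why they did or whether they would on any other core.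

As far as these compounds go, whether a longer chain such as propoxy would also leave the number within the scatter stays open. So does the effect of an amine or a carboxylic acid on the aromatic ring.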